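Replacing 3,4,5-Trimethoxyphenyl with 3,5-Dibromo-4-hydroxyphenyl

The source may report more compounds than this note shows. Statements on the series, on what has been measured and on what is new or still open speak of the compounds shown alone.

In a functional assay on PC-3 cells (Homo sapiens) for cytotoxicity, read by MTT assay, with a stated time of 72 h (a higher number here means a weaker inhibitor, a lower number a stronger inhibitor), compound 1 `O=C(N/N=C/c1cccc(Cl)c1Cl)Nc1cc2c(Nc3ccc(F)c(Cl)c3)ncnc2cc1O[C@H]1CCOC1` gives 27400 nM and compound 2 `COc1cc(/C=N/NC(=O)Nc2cc3c(Nc4ccc(F)c(Cl)c4)ncnc3cc2O[C@H]2CCOC2)cc(OC)c1OC` gives 29600 nM. These two numbers lie within the usual scatter of each other, so compound 2 stands level with compound 1.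

Compound 3 `O=C(N/N=C/c1cc(Br)c(O)c(Br)c1)Nc1cc2c(Nc3ccc(F)c(Cl)c3)ncnc2cc1O[C@H]1CCOC1` differs from compound 2 at a single place: 3,5-dibromo-4-hydroxyphenyl in place of 3,4,5-trimethoxyphenyl on a carbon with a double bond to nitrogen. In words, it carries 3,5-dibromo-4-hydroxyphenyl in place of 3,4,5-trimethoxyphenyl on a carbon with a double bond to nitrogen.

For the measured compounds named here, the only measured step at this place is a 1.1-fold higher number from compound 1 to compound 2 (0.03 log units; within the scatter), which exchanged 2,3-dichlorophenyl for 3,4,5-trimethoxyphenyl and stayed within the scatter. That step offers no reason to expect a large shift, and no direction can be drawn from it. On these data alone, it is still a single step, and neither measured compound has a hydroxy group on this phenyl ring, so that part of the change is untested and the range must stay wide.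

No change beyond the scatter is expected, and the estimated step is a 1.2-fold lower number from compound 2 to compound 3 (0.09 log units; within the scatter). For compound 3, the expected value is 24000 nM, with an estimated range from 10000 nM to 50000 nM.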

Compound 3, half-maximal inhibitory concentration: 6160 nM
The estimate for compound 3 lay 3.9-fold (0.59 log units) above the measured number; measured number below the stated range.
By their numbers in this assay, from the lowest: compound 3; then compounds 1 and 2 (each within the scatter of the next).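

In this assay, for the compounds shown here, the group on the carbon with a double bond to nitrogen now proves able to move the number beyond the scatter: the exchange gives a 4.8-fold lower number from compound 2 to compound 3 (0.68 log units; beyond the scatter), and the comparison with the dichlorinated analogue gives a 4.4-fold lower number from compound 1 to compound 3 (0.65 log units; beyond the scatter), whereas the only earlier step at this place stayed within the scatter. Compound 3 is the only one of the three with steps to both others printed as beyond the scatter, and its 3,5-dibromo-4-hydroxyphenyl group brings one hydrogen-bond donor where 3,4,5-trimethoxyphenyl has none. Nothing available explains the shift, so it cannot be assigned to the hydroxy group, the bromine atoms or the two together.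

The compounds shown leave open which of these parts carries the step, since none has a phenyl ring with the hydroxy group alone or the two bromine atoms alone. They also leave open whether an amine or a carboxylic acid in place of that hydroxy group would keep, extend or lose the lower number.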